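Varying the Benzyl Aryl Group in a Reductase Inhibitor Series

A few compounds are considered here, and "the series" means these few. Any claim that something is new, unique, unknown or untested is made for them only; others in the source may bear on it.

Compound 1 `O=C(O)C[C@H](O)C[C@H](O)CCn1c(-c2ccc(F)cc2)nc(C(=O)NCc2ccccc2F)c1C1CC1`: 1.5 nM
Compound 2 `COc1ccc(CNC(=O)c2nc(-c3ccc(F)cc3)n(CC[C@@H](O)C[C@@H](O)CC(=O)O)c2C2CC2)cc1F`: 3.7 nM
Compound 3 `Cc1ccc(CNC(=O)c2nc(-c3ccc(F)cc3)n(CC[C@@H](O)C[C@@H](O)CC(=O)O)c2C2CC2)cc1`: 1.7 nM

In an assay on microsomes from liver for inhibition of 3-hydroxy-3-methylglutaryl-coenzyme A reductase (Rattus norvegicus), read by scintillation counting, with stated times of 0.5 h and 0.75 h (on this read-out higher numbers stand for weaker inhibition and lower numbers for stronger inhibition), compound 1 gives the lowest number of the three measured compounds. The three share one core and differ only in the aryl group on a saturated chain carbon bound to an amide-type nitrogen. The step of a 2.5-fold higher number from compound 1 to compound 2 (0.39 log units; beyond the scatter) was a modest loss, whereas a 1.1-fold higher number from compound 1 to compound 3 (0.05 log units; within the scatter) stayed within the scatter. Compound 4 `CN(C)S(=O)(=O)c1ccc(CNC(=O)c2nc(-c3ccc(F)cc3)n(CC[C@@H](O)C[C@@H](O)CC(=O)O)c2C2CC2)cc1` carries 4-(dimethylsulfamoyl)phenyl in place of 2-fluorophenyl on a saturated chain carbon bound to an amide-type nitrogen. Both measured steps bear on this change, since each swaps the same aryl group; the larger, more substituted ring of compound 2 cost a modest step, the simple methyl of compound 3 cost nothing. A modest weakening is therefore expected for compound 4, in the form of a 2.3-fold higher number from compound 1 to compound 4 (0.37 log units; beyond the scatter). The estimate for compound 4 in this assay is 3.5 nM, with a range from 1.5 nM to 9 nM.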

Compound 4, half-maximal inhibitory concentration in the 3-hydroxy-3-methylglutaryl-coenzyme A reductase assay: 4.9 nM
Compound 4: middle estimate off by 1.4-fold (0.15 log units), on the low side; the measured number falls inside the stated range.
By their numbers in the 3-hydroxy-3-methylglutaryl-coenzyme A reductase assay, from the lowest: compounds 1 and 3 (each within the scatter of the next); then compounds 2 and 4 (each within the scatter of the next).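

In the 3-hydroxy-3-methylglutaryl-coenzyme A reductase assay, the 4-(dimethylsulfamoyl)phenyl group shows a 3.3-fold higher number from compound 1 to compound 4 (0.51 log units; beyond the scatter) and a 2.9-fold higher number from compound 3 to compound 4 (0.46 log units; beyond the scatter), while a 1.3-fold higher number from compound 2 to compound 4 (0.12 log units; within the scatter). This position thus accepts a ring bearing a dimethylsulfamoyl group, with hydrogen-bond acceptors the earlier aryl groups do not count, at only a modest cost in inhibition. The same change also shifts lipophilicity in a physicochemical assay for lipophilicity, using the shake flask method, at pH 7.4; on this read-out higher numbers stand for higher lipophilicity and lower numbers for lower lipophilicity: the measured distribution coefficient of compound 1, 0.08, and of compound 4, -0.46, a number 0.54 log units lower (beyond the scatter) In the physicochemical assay compound 1 gives 0.08 and compound 4 gives -0.46.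

The compounds shown leave open whether the weaker inhibition is tied to that lower lipophilicity. Also open, on these data alone, is how an amine or a carboxylic acid in place of dimethylsulfamoyl would read in the 3-hydroxy-3-methylglutaryl-coenzyme A reductase assay.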